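The compounds below may be only part of what the source reports. "The series", "measured", "known", "first", "only" and "open" are said of these compounds alone.

Working notes on the series. Going by the values given here, compound 1 `CC(C)C[C@H](N)c1cc(C(F)(F)F)ccc1N1CCN(C(=O)COc2ccc(O)cc2)CC1` is measured in an assay on HEK293 cells for displacement of a labelled ligand from Melanocortin receptor 4 (Homo sapiens) (on this read-out lower numbers stand for stronger inhibition and higher numbers for weaker inhibition), at 4600 nM, the highest of the two numbers so far. Compound 2 `CC(C)C[C@H](N)c1cc(C(F)(F)F)ccc1N1CCN(C(=O)CNc2ccccc2)CC1` gives 3600 nM in this assay, and the step of a 1.3-fold lower number from compound 1 to compound 2 (0.11 log units; within the scatter) shows that exchanging the whole 4-hydroxyphenoxy for anilino at the saturated chain carbon bound to the carbonyl carbon leaves the number within the scatter. Compound 3 `CC(C)C[C@H](N)c1cc(C(F)(F)F)ccc1N1CCN(C(=O)COc2ccc(Cl)cc2)CC1` differs from compound 1 by chloro in place of hydroxy on an aromatic carbon, that is, 4-hydroxyphenoxy becomes 4-chlorophenoxy. Among the compounds with values here, no measured step touches this substituent directly; the only related comparison, from compound 1 to compound 2, was within the scatter, so there is no basis here for expecting a step beyond the scatter in this assay. The step from compound 1 to compound 3 is therefore expected at about a 1.3-fold lower number from compound 1 to compound 3 (0.12 log units; within the scatter). Compound 3 is estimated at 3500 nM, with a range from 1200 nM to 10000 nM.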

Compound 3, inhibition constant: 2900 nM
For compound 3 the middle estimate is 1.2-fold (0.08 log units) above the measured one, within the range that was stated.
By their numbers in this assay, from the lowest: compounds 3, 2 and 1 (each within the scatter of the next).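

On the aromatic carbon para to a large group, chloro in place of hydroxy gives a 1.6-fold lower number from compound 1 to compound 3 (0.20 log units; within the scatter) in this assay. This is the first direct reading of this substituent, and the number stays within the scatter although the hydrogen-bond donor and acceptor of the hydroxy leave with it; likewise, 4-chlorophenoxy in place of anilino gives a 1.2-fold lower number from compound 2 to compound 3 (0.09 log units; within the scatter), so no pair among the three compounds shown stands beyond the scatter. Nothing available explains why the number holds at this position.

Going by these compounds, whether an amine or a carboxylic acid on this aromatic carbon would give a step beyond the scatter remains open. So does the outcome of a longer chain in place of (4-chlorophenoxy)methyl.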